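The source may report more compounds than this note shows. Statements on the series, on what has been measured and on what is new or still open speak of the compounds shown alone.

Of the compounds shown here, two carry numbers so far. Compound 1 `N#Cc1ccc(CNc2c(NC3CCCC3)c(=O)c2=O)cc1` gives 9400 nM in a functional assay for inhibition, with Rattus norvegicus as the target; a higher number here means a weaker inhibitor, a lower number a stronger inhibitor. Compound 2 `CC[C@H](C)/N=c1\c(O)c(O)\c1=N/Cc1ccc(C#N)cc1` gives 2200 nM in this assay. Of the two numbers, compound 2 holds the lower one; its nearest neighbour is compound 1, and the gap between them lies beyond the scatter. Compound 3 `CCC(C)(C)/N=c1\c(O)c(O)\c1=N/Cc1ccc(C#N)cc1` has not yet been measured. It differs from compound 2 in one place: 1,1-dimethylpropyl in place of sec-butyl on a double-bonded nitrogen. Within the data shown here, no step between two measured compounds bears on an alkyl change of this kind, so nothing in the data points to a direction; the change keeps the rest of compound 2 intact, and the nitrile-bearing benzyl side is shared with both measured compounds. In this assay the expected step is small, a 1.3-fold higher number from compound 2 to compound 3 (0.10 log units; within the scatter), and not beyond the scatter. For compound 3 the estimate in this assay is 2800 nM, with a range from 900 nM to 9000 nM.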

Compound 3, half-maximal inhibitory concentration: 1100 nM
The estimate for compound 3 lay 2.5-fold (0.41 log units) above the measured number; low and high end bracket the measured number.
By their numbers in this assay, from the lowest: compounds 3 and 2 (each within the scatter of the next); then compound 1.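

In this assay, 1,1-dimethylpropyl in place of sec-butyl on a double-bonded nitrogen gives a 2.0-fold lower number from compound 2 to compound 3 (0.30 log units; within the scatter), so this position takes the chain with one more carbon without a step beyond the scatter. The defined stereocentre of sec-butyl is absent from the entering group, and the number stays within the scatter, so that stereocentre is not needed to hold a number at this level. No measurement shown accounts for how close the two numbers lie.

Still open, from the compounds shown here alone, is how this position responds to an alkyl chain ending in an amine or a carboxylic acid, or to a longer chain such as n-hexyl. The benzyl side also remains open, as all the compounds shown keep its nitrile; a carboxylic acid or an amide there would test that part.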